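This account rests on a few compounds, and the source may have more. Where it says the series, first, only, none or still open, it means among the compounds named here.

Two compounds of one series have been examined in a functional assay on the whole organism (strain Swiss albino) with Mus musculus as the target, in the maximal electroshock model, with a stated time of 0.5 h; a lower number here means that less compound is needed, a higher number that more compound is needed for the effect. Compound 1 `O=C(N/N=C/c1ccc(Cl)cc1Cl)Nc1cccc2ccccc12` carries a dichlorinated aromatic ring on the hydrazone side of the shared core, and in this assay compound 1 gives 100 mg/kg. Compound 2 `COc1ccc(/C=N/NC(=O)Nc2cccc3ccccc23)cc1OC` carries two methoxy groups on that ring instead, and in this assay compound 2 gives 100 mg/kg. Compound 2 thus stands level with compound 1 at the digits reported; the two values lie within the scatter of one another, so no order can be drawn between them.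

Compound 3 `COc1ccc(/C=N/NC(=O)Nc2cccc3ccccc23)cc1` is the next member. Relative to compound 2 the change is hydrogen in place of methoxy on an aromatic carbon, the place being ortho to a methoxy group and meta to a large group. No direct comparison between measured compounds informs this change. Since compound 1 and compound 2 give the same reading despite different substitution on that ring, the expected step from compound 2 to compound 3 is no change at the digits printed from compound 2 to compound 3 (within the scatter), none beyond the scatter. Compound 3 is therefore expected to give about 100 mg/kg, within a range of 50 mg/kg to 300 mg/kg.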

Compound 3, minimum effective dose: 300 mg/kg
For compound 3 the middle estimate is 3.0-fold (0.48 log units) below the measured one; low and high end bracket the measured number.
By their numbers in this assay, from the lowest: compounds 1 and 2 (each within the scatter of the next); then compound 3.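

In this assay, hydrogen in place of methoxy on this aromatic carbon, ortho to a methoxy group and meta to a large group, gives a 3.0-fold higher number from compound 2 to compound 3 (0.48 log units; beyond the scatter). This position is therefore not indifferent to its substituent, which the level readings of the first two compounds could not show. Read against the dichlorinated compound, 4-methoxyphenyl in place of 2,4-dichlorophenyl gives a 3.0-fold higher number from compound 1 to compound 3 (0.48 log units; beyond the scatter), so among these three compounds the ring bearing the single methoxy group is the one that needs more compound for the effect, while the two differently substituted rings stay level with each other. Nothing available explains why this change raises the number.

The compounds shown leave open whether methoxy itself is needed at this place or whether another group, such as hydroxyl, fluorine or an amine, would hold the number at the level of compound 2. They also leave open whether the step depends on the methoxy group that stays on the ring, as a compound with hydrogen at that carbon and a hydroxyl or ethoxy group at the other would be needed to separate the two places.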